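Methoxy in Place of Bromo: Estimating Compound 4

A few compounds are considered here, and "the series" means these few. Any claim that something is new, unique, unknown or untested is made for them only; others in the source may bear on it.

Measured so far:
Compound 1 `O=C(NCc1ccc(Br)cc1)N1C(=O)c2ccccc2S1(=O)=O`: 0.187 h
Compound 2 `O=C(NCc1cccc(Br)c1)N1C(=O)c2ccccc2S1(=O)=O`: 0.492 h
Compound 3 `CC(NC(=O)N1C(=O)c2ccccc2S1(=O)=O)c1ccccc1`: 0.663 h

In a physicochemical assay for pharmacokinetics (on this read-out lower numbers stand for a shorter-lived compound and higher numbers for a longer-lived compound), compound 2 stands second highest of the three numbers. Among the compounds with values here, compound 3 lies within the scatter of it, while the only counted step, a 2.6-fold higher number from compound 1 to compound 2 (0.42 log units; beyond the scatter), is a modest one in which 3-bromophenyl replaced 4-bromophenyl. Compound 4 `COc1cccc(CNC(=O)N2C(=O)c3ccccc3S2(=O)=O)c1` is the unmeasured partner of compound 2: methoxy in place of bromo on an aromatic carbon, so the move reads 3-bromophenyl to 3-methoxyphenyl. Within the data shown here, no measured pair exchanges bromo for methoxy, so the one known step gives only a sense of how far a ring-substituent change has shifted this assay. The step to compound 4 is therefore expected to stay within the scatter, a 1.0-fold higher number from compound 2 to compound 4 (0.01 log units; within the scatter), and compound 4 is estimated at 0.5 h, between 0.2 h and 1.2 h.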

Compound 4, half-life: 0.523 h
The estimate for compound 4 lay 1.0-fold (0.02 log units) below the measured number; low and high end bracket the measured number.
By their numbers in this assay, from the lowest: compound 1; then compounds 2, 4 and 3 (each within the scatter of the next).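

In this assay bromo and methoxy on this aromatic carbon cannot be told apart, with a 1.1-fold higher number from compound 2 to compound 4 (0.03 log units; within the scatter) even though methoxy brings a hydrogen-bond acceptor that bromo lacks. The low end stays with the 4-bromophenyl group, as a 2.8-fold higher number from compound 1 to compound 4 (0.45 log units; beyond the scatter) shows with 3-methoxyphenyl in its place. No evidence at hand explains either result. As far as these compounds go, whether 4-methoxyphenyl would sit with compound 1 or with compound 4 remains open. So does whether an amine or a carboxylic acid on this carbon would also leave the number unmoved.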